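Swapping chloro for fluoro on the benzyl group of compound 2

The source may report more compounds than this note shows. Statements on the series, on what has been measured and on what is new or still open speak of the compounds shown alone.

Measured so far:
compound 1 `O=C1N=C(Nc2ccc(F)c(Cl)c2)S/C1=C\c1ccc(-c2ccc(C(=O)O)c(O)c2)o1` in an ADME assay on HEK293 cells (Homo sapiens) for inhibition, read by MTT assay, with a stated time of 2 days (on this read-out higher numbers stand for weaker inhibition and lower numbers for stronger inhibition), compound 1 gives 12000 nM
compound 2 `O=C1/C(=C/c2ccc(-c3cc(C(F)(F)F)ccc3Cl)o2)SC(=S)N1Cc1ccc(Cl)cc1` in this assay compound 2 gives 4200 nM

Of these two numbers, compound 2 has the lower one, and the gap to compound 1 lies beyond the usual scatter of repeated measurements, so compound 2 is the stronger inhibitor in this assay on the evidence at hand.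

Compound 3 `O=C1/C(=C/c2ccc(-c3cc(C(F)(F)F)ccc3Cl)o2)SC(=S)N1Cc1ccc(F)cc1` is not yet measured. It differs from compound 2 in a single place: fluoro in place of chloro on an aromatic carbon, para to a large group. Among the compounds with values here, no pair of measured compounds shows what such a one-atom swap does here, so the expectation rests on compound 2 alone.

Such a small change is expected to move the number little, if at all, so the step of a 1.3-fold higher number from compound 2 to compound 3 (0.12 log units; within the scatter) is expected to stay within the scatter, perhaps slightly weaker. For compound 3 in this assay the estimate is 5500 nM, with a range from 2000 nM to 15000 nM.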

Compound 3, half-maximal inhibitory concentration: 2400 nM
The estimate for compound 3 lay 2.3-fold (0.36 log units) above the measured number, and the stated range covers the measured number.
By their numbers in this assay, from the lowest: compounds 3 and 2 (each within the scatter of the next); then compound 1.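

In this assay, within the data shown here, putting fluoro in place of chloro on the 4-chlorobenzyl group gives a 1.8-fold lower number from compound 2 to compound 3 (0.24 log units; within the scatter), the first step here between compounds that differ in only one place. The two compounds therefore cannot be told apart in this assay. At this position, chloro and fluoro are interchangeable as far as this read-out can show, although this rests on a single pair. No measurement shown here offers an explanation for this result.

From the compounds shown here alone, it remains open whether a different kind of group at this position, such as an amine, a carboxylic acid or a longer chain, would give a number clearly apart from these two. Going by these compounds, it is also open whether the same one-atom swap would give a similar result elsewhere on the shared core.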